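Thiophene in place of methylphenyl on a shared core

The source may report more compounds than this note shows. Statements on the series, on what has been measured and on what is new or still open speak of the compounds shown alone.

Measured compounds:
compound 1 `NC(COCc1ccccc1)c1cc(F)ccc1N1CCN(C(=O)CCc2ccc(Cl)cc2Cl)CC1` with 1000 nM;
compound 2 `CCC(C)[C@H](N)c1cc(C(F)(F)F)ccc1N1CCN(C(=O)CCc2ccc(OC)c(OC)c2Cl)CC1` with 2500 nM;
compound 3 `Cc1cccc(CCC(=O)N2CCN(c3ccc(C(F)(F)F)cc3[C@@H](N)CC(C)C)CC2)c1` with 2100 nM.

All three were tested in an assay on HEK293 cells for displacement of a labelled ligand from Melanocortin receptor 4 (Homo sapiens); on this read-out lower numbers stand for stronger inhibition and higher numbers for weaker inhibition. Compound 3 stands second highest of the three numbers. Compound 2 sits nearest to it, a difference within the scatter, so nothing separates them. Compound 1 gives the lower number, and that gap lies beyond the scatter.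

Compound 4 `CC(C)C[C@H](N)c1cc(C(F)(F)F)ccc1N1CCN(C(=O)CCc2cccs2)CC1` has not yet been measured. It keeps the core of compound 3 and differs in one place: thiophen-2-yl in place of 3-methylphenyl on a saturated chain carbon, two bonds along the chain from a carbonyl carbon. Going by the values given here, no step between two measured compounds isolates such a change, so the expectation rests on compound 3 alone, which gives 2100 nM in this assay. With nothing else to go on, the step of a 1.2-fold higher number from compound 3 to compound 4 (0.08 log units; within the scatter) is expected to stay small, most likely within the scatter, in either direction. Compound 4 is therefore estimated at 2500 nM, with a range from 800 nM to 8000 nM.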

Compound 4, inhibition constant: 4600 nM
Compound 4: middle estimate off by 1.8-fold (0.26 log units), on the low side, and the stated range covers the measured number.
By their numbers in this assay, from the lowest: compound 1; then compounds 3, 2 and 4 (each within the scatter of the next, the first and the last beyond it).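

In this assay, going by these compounds alone, thiophen-2-yl in place of 3-methylphenyl on a saturated chain carbon, two bonds along the chain from a carbonyl carbon, gives a 2.2-fold higher number from compound 3 to compound 4 (0.34 log units; beyond the scatter), the first step here that isolates a single change. It shows that this place is not indifferent to the aromatic ring it carries: exchanging a six-membered ring of carbon only for a five-membered ring with one sulfur moves the number modestly towards weaker inhibition. No measurement is available that would explain this shift.

The compounds shown leave open whether the step follows from the sulfur, the ring size or the lost methyl group. Going by these compounds, how phenyl, thiophen-3-yl or furan-2-yl would read at this place on the shared core also remains unknown.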